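The source may report more compounds than this note shows. Statements on the series, on what has been measured and on what is new or still open speak of the compounds shown alone.

Measured so far in an assay on isolated protein for inhibition of serine/threonine-protein kinase TNNI3K (Homo sapiens); on this read-out higher numbers stand for weaker inhibition and lower numbers for stronger inhibition:
compound 1 `CNc1cc(Oc2ccc(NC(=O)Nc3cccc(C(F)F)c3)cc2)ncn1` gives 100 nM;
compound 2 `Nc1cc(Oc2ccc(NC(=O)Nc3cccc(C(F)(F)F)c3)cc2)ncn1` gives 25 nM.

Of these two numbers, compound 2 holds the lower one, and its gap to compound 1 lies beyond the usual scatter. Compound 3 `O=C(Nc1ccc(Oc2ccncc2)cc1)Nc1cccc(C(F)(F)F)c1` has not yet been measured. It differs from compound 2 by one change: pyridin-4-yl in place of 6-aminopyrimidin-4-yl on an oxygen on an aromatic ring. Within the data shown here, no measured pair shows this change, so its effect is not known from the data. The step from compound 2 to compound 3 in this assay is expected to be a 6.0-fold higher number from compound 2 to compound 3 (0.78 log units; beyond the scatter), a weakening, because the donor of compound 2 goes with 25 nM. Compound 3 is estimated at 150 nM, with a range from 40 nM to 600 nM.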

Compound 3, half-maximal inhibitory concentration: 50 nM
Compound 3: middle estimate off by 3.0-fold (0.48 log units), on the high side; the range from low to high includes it.
By their numbers in this assay, from the lowest: compounds 2, 3 and 1 (each within the scatter of the next, the first and the last beyond it).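

In this assay, putting pyridin-4-yl in place of 6-aminopyrimidin-4-yl on an oxygen on an aromatic ring gives a 2.0-fold higher number from compound 2 to compound 3 (0.30 log units; within the scatter), so this one pair shows that the position accepts the exchange within the scatter. The entering group has 0 hydrogen-bond donors, yet compound 3 cannot be told apart from compound 2 on this read-out. Nothing available gives a reason for this step. Left open is what an amine on the pyridin-4-yl ring would do, and whether a methoxy group or a carboxylic acid would be accepted there.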